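A few compounds are considered here, and "the series" means these few. Any claim that something is new, unique, unknown or untested is made for them only; others in the source may bear on it.

Of the compounds shown here, three sharing one core have been measured in an ADME assay on J774.A1 cells (Mus musculus) for cytotoxicity, read by MTT assay, with a stated time of 72 h; a higher number here means a weaker inhibitor, a lower number a stronger inhibitor. Compound 1 (`CC(=O)c1c(C)[n+]([O-])c2cc(-n3ccnc3)c(F)cc2[n+]1[O-]`) gives 77700 nM, compound 2 (`CCOC(=O)c1c(C)[n+]([O-])c2cc(-n3ccnc3)c(F)cc2[n+]1[O-]`) gives 77700 nM, and compound 3 (`CCOC(=O)c1c(C)[n+]([O-])c2cc(-n3cncn3)c(F)cc2[n+]1[O-]`) gives 77700 nM. Compound 2 therefore stands level with both of the others at the digits available.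

The next compound, compound 4 (`Cc1c(C(=O)OC(C)C)[n+]([O-])c2cc(F)c(-n3ccnc3)cc2[n+]1[O-]`), departs from compound 2 at the ester, where ethoxycarbonyl becomes isopropoxycarbonyl: methyl in place of hydrogen on a saturated chain carbon bound to an oxygen next to a carbonyl group and a saturated chain carbon.

Among the compounds with values here, two measured steps bear on this change. The closer one alters the same carbonyl substituent, with ethoxy in place of methyl on a carbonyl carbon, and it shows no change at the digits printed from compound 1 to compound 2 (within the scatter). The other, with 1H-1,2,4-triazol-1-yl in place of 1H-imidazol-1-yl on an aromatic carbon, shows no change at the digits printed from compound 2 to compound 3 (within the scatter). Within the data shown here, neither step moved the value in this assay, although no compound with a branched ester has yet been measured there.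

On these three compounds alone, no shift beyond the scatter is expected, in either direction. The estimated step is no change at the digits printed from compound 2 to compound 4 (within the scatter). For compound 4 the expected value is 77700 nM, with an estimated range of 40000 nM to 100000 nM.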

Compound 4, half-maximal inhibitory concentration: 77700 nM
Beside the measured number, compound 4's estimate shows no gap at the digits printed; the range from low to high includes it.
By their numbers in this assay, from the lowest: compounds 1, 2, 3 and 4 (each within the scatter of the next).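

In this assay, the carbonyl substituents shown so far had been methyl and ethoxy, and compound 4 extends this series to a branched ester: methyl in place of hydrogen on the saturated chain carbon bound to the oxygen gives no change at the digits printed from compound 2 to compound 4 (within the scatter). The larger replacement, which swaps the methyl on this carbonyl for isopropoxy, gives no change at the digits printed from compound 1 to compound 4 (within the scatter), so methyl, ethoxy and isopropoxy on this carbonyl all read alike at the digits printed in compounds 1, 2 and 4, and branching at this chain carbon adds no step beyond the scatter. Nothing available explains why the read-out stays level across these groups.

The compounds shown leave open whether this level reading would hold with a carboxylic acid, an amide, or a longer chain such as a butyl or benzyl ester at the same carbonyl. They also leave open whether isopropoxycarbonyl would read the same alongside 1H-1,2,4-triazol-1-yl on the shared core.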